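A few compounds are considered here, and "the series" means these few. Any claim that something is new, unique, unknown or untested is made for them only; others in the source may bear on it.

Compound 1 `COc1ccc(-c2cnc(NC(=O)c3ncc[nH]3)n2C)cc1` was examined in a toxicity assay on THP-1 cells (Homo sapiens) for inhibition; a lower number here means that less compound is tolerated, a higher number that more compound is tolerated. In this assay compound 1 gives > 100000 nM, which is a limit of the assay rather than a number. Two other compounds were run in the same assay. Compound 2 `COc1ccc(-c2cnc(NC(=O)c3ccc(F)cc3)n2-c2ccccc2)cc1` in this assay gives 8800 nM. Compound 3 `COc1ccc(-c2ccnc(NC(=O)c3ccc(F)cc3)c2)cc1` in this assay gives > 100000 nM, again a limit of the assay and not a number. Compound 1 thus sits at the limit of > 100000 nM in this assay, at which 2 of the 3 values shown sit, the same place compound 3 occupies, while compound 2 alone returns a measured number.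

Compound 4 `COc1ccc(-c2cnc(NC(=O)c3ccccc3F)n2C)cc1` has not yet been measured. It differs from compound 1 in one place: 2-fluorophenyl in place of 1H-imidazol-2-yl on a carbonyl carbon. Compound 3 also carries an amide of a fluorinated benzene ring on its carbonyl and still stops at a limit in this assay, whereas compound 2 carries one and gives a number, so that change by itself does not decide the outcome. Compound 4 is therefore expected to remain close to the limit, with a step of an at least 1.2-fold lower number from compound 1 to compound 4 (0.09 log units; that floor lies within the scatter) that is expected to stay within the scatter. Compound 4 is estimated to give 80000 nM in this assay, ranging from 20000 nM to 200000 nM.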

Compound 4, half-maximal cytotoxic concentration: > 100000 nM
Compound 4: only a limit was reported; the forecaster's own chance of this, stated with the estimate: 55%; at least 1.2-fold (0.09 log units) between middle value and limit.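

Compound 1 and compound 4 each stop at a limit rather than a number in this assay, so the step between them cannot be read: the limit of > 100000 nM in this assay, at which 3 of the 4 values shown sit.

The compounds shown leave open where the true values of compound 1 and compound 4 lie, and whether this change on the carbonyl carbon shifts tolerance at all.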